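The compounds below may be only part of what the source reports. "The series", "measured", "known", "first", "only" and "open" are said of these compounds alone.

Measured so far in a functional assay on Caco-2 cells (Homo sapiens) for cytotoxicity, read by MTT assay, with a stated time of 48 h; on this read-out lower numbers stand for stronger inhibition and higher numbers for weaker inhibition:
compound 1 `COc1cc(/C=C/C(=O)/C=C(/C=C/c2ccc(O)c(OC)c2)NCCO)ccc1O` gives 87200 nM
compound 2 `COc1cc(/C=C/C2=CC(=O)CC(c3ccc(O)c(OC)c3)N2CCCO)ccc1O` gives 88000 nM
compound 3 `O=C(/C=C(/C=C/c1ccc(O)cc1)NCCCO)/C=C/c1ccc(O)cc1` gives 31600 nM

Compound 1 lies within the scatter of compound 2, while compound 3 gives a lower number, beyond the scatter. Compound 4 `COc1cc(/C=C/C(=O)/C=C(/C=C/c2ccc(O)c(OC)c2)NCCCO)ccc1O` has not yet been measured. The change hydroxymethyl in place of hydroxy on a saturated chain carbon, two bonds along the chain from an amine nitrogen places hydroxymethyl in place of hydroxy on a saturated chain carbon, two bonds along the chain from an amine nitrogen. Among the measured compounds shown here, no measured pair shows this change alone, so no shift beyond the scatter is expected. The expected 1.2-fold lower number from compound 1 to compound 4 (0.10 log units; within the scatter) is a small one. Compound 4 is estimated at 70000 nM with an expected range of 32000 nM to 130000 nM in this assay.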

Compound 4, half-maximal inhibitory concentration: 75700 nM
For compound 4 the middle estimate is 1.1-fold (0.03 log units) below the measured one; low and high end bracket the measured number.
By their numbers in this assay, from the lowest: compound 3; then compounds 4, 1 and 2 (each within the scatter of the next).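

In this assay the change from (2-hydroxyethyl)amino to (3-hydroxypropyl)amino gives a 1.2-fold lower number from compound 1 to compound 4 (0.06 log units; within the scatter) and so provides the first measured pair showing this change alone. At this place, on a saturated chain carbon, two bonds along the chain from an amine nitrogen, hydroxymethyl in place of hydroxy produces no shift beyond the scatter. No measurement shown bears on why this is so. Going by these compounds, whether a 4-hydroxybutyl chain or a carboxylic acid in place of the hydroxy group would also stay within the scatter remains open. This reading also rests on a single pair.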